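Ring Closure at the Acid-Bearing Carbon

The source may report more compounds than this note shows. Statements on the series, on what has been measured and on what is new or still open speak of the compounds shown alone.

Compound 1 `Cc1cc(OC[C@@H]2CN(C)c3ccccc3O2)cc(C)c1C(=O)Nc1cc(CC(=O)O)ccc1Cl` and compound 2 `Cc1cc(OC[C@@H]2CN(C)c3ccccc3O2)cc(C)c1C(=O)Nc1cc(C(C)(C)C(=O)O)ccc1Cl` share one core and differ only in the acid-bearing group. In an assay on CHO cells for displacement of a labelled ligand from prostacyclin receptor (Homo sapiens), read by scintillation counting, with a stated time of 30 min (on this read-out lower numbers stand for stronger inhibition and higher numbers for weaker inhibition), compound 1 gives a limit of > 10000 nM. In this assay compound 2 likewise gives only a limit, > 10000 nM. The step that the two limits leave unreadable from compound 1 to compound 2 therefore cannot be read, and the limit of > 10000 nM in this assay, at which 2 of the 2 values shown sit, is where both values sit. Compound 3 `Cc1cc(OC[C@@H]2CN(C)c3ccccc3O2)cc(C)c1C(=O)Nc1cc(C2(C(=O)O)CC2)ccc1Cl` carries 1-carboxycyclopropyl in place of 1-carboxy-1-methylethyl on an aromatic carbon. No readable step bears on this change, so compound 3 is expected to stay at the limit. The step that the limit leaves unreadable from compound 2 to compound 3 is expected to be none beyond the scatter. For compound 3 the estimated value is 15000 nM, with a range from 5000 nM to 50000 nM.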

Compound 3, inhibition constant in the prostacyclin receptor assay: > 10000 nM
Compound 3 ended at the assay's limit (the forecaster's own chance of this, stated with the estimate: 80%); the middle value does not contradict the limit.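

In the prostacyclin receptor assay compound 3 gives only a limit, > 10000 nM. No step among compound 1, compound 2 and compound 3 can therefore be read: the limit of > 10000 nM in the prostacyclin receptor assay, at which 3 of the 3 values shown sit.

The compounds shown leave open what inhibition constant each of the three actually has.

In a physicochemical assay for solubility, measured as kinetic solubility (a lower number here means a less soluble compound, a higher number a more soluble compound), compound 2 gives 490 ug/mL and compound 3 gives 321 ug/mL. In the physicochemical assay the step is a 1.5-fold lower number from compound 2 to compound 3 (0.18 log units; within the scatter).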